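Methylamino for methylsulfamoyl on the side chain of compound 3

A few compounds are considered here, and "the series" means these few. Any claim that something is new, unique, unknown or untested is made for them only; others in the source may bear on it.

Compound 1 `Nc1ccc2nc(N)sc2c1`: in a functional assay on the whole organism with Rattus norvegicus as the target (on this read-out lower numbers stand for an effect already at smaller amounts and higher numbers for an effect only at larger amounts of compound), compound 1 gives > 10 mg/kg, a limit of the assay.
Compound 2 `CC(C)(C)Oc1ccc2nc(N)sc2c1`: in this assay compound 2 gives > 10 mg/kg, likewise a limit.
Compound 3 `CNS(=O)(=O)CCn1c(=N)sc2cc(OC(F)(F)F)ccc21`: in this assay compound 3 gives 4 mg/kg.

Compound 3 holds the only number among these three values; the other two are limits, namely (the limit of > 10 mg/kg in this assay, at which 2 of the 3 values shown sit). The step that the two limits leave unreadable from compound 1 to compound 2 cannot be read for this reason, and it concerns a change on an aromatic carbon unlike the one followed here. Compound 4 `CNCCn1c(=N)sc2cc(OC(F)(F)F)ccc21` differs from compound 3 by methylamino in place of methylsulfamoyl on a saturated chain carbon, two bonds along the chain from an aromatic nitrogen. Going by the values given here, no measured step bears on this change, so the data give no footing for a shift beyond the scatter in either direction. Compound 4 is therefore estimated at 5 mg/kg in this assay, between 2 mg/kg and 15 mg/kg. The step of a 1.3-fold higher number from compound 3 to compound 4 (0.10 log units; within the scatter) is thus expected to stay within the usual scatter.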

Compound 4, dose for half-maximal effect: > 10 mg/kg
Compound 4 was reported as a limit (the forecaster's own chance of this, stated with the estimate: 25%); middle value at least 2.0-fold (0.30 log units) from the limit.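

Here the side chain gives the first readable step of the series: in this assay, the change gives an at least 2.5-fold higher number from compound 3 to compound 4 (0.39 log units; beyond the scatter). Methylamino therefore does not stand in for methylsulfamoyl at this position without a loss on this read-out, against what the earlier compounds could indicate. Compound 4 ends at a limit, so compound 3 alone keeps a number: the limit of > 10 mg/kg in this assay, at which 3 of the 4 values shown sit.

Going by these compounds, how large the step truly is stays open. So does whether a carboxamide, a carboxylic acid or a longer chain carrying the methylsulfamoyl group would keep the effect of compound 3.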